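A few compounds are considered here, and "the series" means these few. Any claim that something is new, unique, unknown or untested is made for them only; others in the source may bear on it.

Compound 1 `c1ccc(C2=NN(C3=NC(c4ccccc4)CS3)C(c3cccc4ccccc34)C2)cc1` carries a naphthalen-1-yl group on a saturated ring carbon of the shared core and a phenyl group on a carbon with a double bond to nitrogen. In a functional assay on HepG2 cells (Homo sapiens) for inhibition, read by CCK-8 assay, with a stated time of 48 h (on this read-out higher numbers stand for weaker inhibition and lower numbers for stronger inhibition), compound 1 gives 13200 nM. Its only measured companion, compound 2 `c1ccc(C2=NN(C3=NC(c4ccccc4)CS3)C(c3ccc4ccccc4c3)C2)cc1`, gives 17200 nM in this assay, and the step of a 1.3-fold higher number from compound 1 to compound 2 (0.11 log units; within the scatter) is within the scatter, so the two compounds cannot be told apart on these numbers; compound 1 simply stands beside compound 2.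

Compound 3 `Cc1ccc(C2=NN(C3=NC(c4ccccc4)CS3)C(c3cccc4ccccc34)C2)cc1C` has not yet been measured. It differs from compound 1 at one place: 3,4-dimethylphenyl in place of phenyl on a carbon with a double bond to nitrogen. Among the compounds with values here, no measured step touches this part of the core; the one measured step, from compound 1 to compound 2, alters a different position and stays within the scatter, so it gives no direction for the present change. The reasonable expectation is therefore a step of no clear size beyond the scatter, a 1.0-fold lower number from compound 1 to compound 3 (0.01 log units; within the scatter). On that basis compound 3 is estimated at 13000 nM in this assay, with a plausible range from 5000 nM to 35000 nM.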

Compound 3, half-maximal inhibitory concentration: 7250 nM
Beside the measured number, compound 3's estimate is 1.8-fold (0.25 log units) above it; the measured number falls inside the stated range.
By their numbers in this assay, from the lowest: compounds 3, 1 and 2 (each within the scatter of the next, the first and the last beyond it).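

In this assay, within the data shown here, the exchange of phenyl for 3,4-dimethylphenyl on a carbon with a double bond to nitrogen gives the first measured step at this position of the shared core: a 1.8-fold lower number from compound 1 to compound 3 (0.26 log units; within the scatter). The step lies within the scatter, so compound 1 and compound 3 cannot be told apart on these numbers, and the two added methyl groups on this ring leave the reading indistinguishable from that of the unsubstituted phenyl group; the earlier pair, which changed only the naphthyl attachment, could say nothing about this position. No measurement at hand bears on why the read-out stays within the scatter here.

On these data alone, with a single substituted phenyl group at this position, it remains open whether any replacement here can move the number beyond the scatter, for instance an amine, a carboxylic acid or a methoxy group on the ring, or a longer alkyl chain in place of the ring. As far as these compounds go, it is equally open whether 3,4-dimethylphenyl would read the same alongside naphthalen-2-yl as it does alongside naphthalen-1-yl.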